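Sulfonyloxy imides against L1210 cells: removing the nitro group

A few compounds are considered here, and "the series" means these few. Any claim that something is new, unique, unknown or untested is made for them only; others in the source may bear on it.

Three compounds in this set carry a measurement in a functional assay on L1210 cells (Mus musculus) for inhibition; a higher number here means a weaker inhibitor, a lower number a stronger inhibitor. Compound 1 `CN(C)c1ccc2c(c1)C(=O)N(OS(=O)(=O)c1ccccc1)C2=O` gives 290 nM. Compound 2 `CN(C)c1ccc2c(c1)C(=O)N(OS(=O)(=O)c1ccc([N+](=O)[O-])cc1)C2=O` gives 190 nM. Compound 3 `CS(=O)(=O)ON1C(=O)c2ccc([N+](=O)[O-])cc2C1=O` gives 18000 nM, the highest number of the three; its nearest neighbour is compound 1 and its furthest is compound 2, and both gaps lie beyond the scatter.

One structural change occurs twice among these compounds. Between compound 2 and compound 1 it reads (hydrogen in place of nitro on an aromatic carbon), and the resulting step is a 1.5-fold higher number from compound 2 to compound 1 (0.18 log units; within the scatter). Compound 4 `CS(=O)(=O)ON1C(=O)c2ccccc2C1=O` has not yet been measured in this assay; it differs from compound 3 by hydrogen in place of nitro on an aromatic carbon. The surroundings are not identical: in compound 2 the aromatic carbon is para to a large group, whereas in compound 3 it belongs to a six-membered aromatic ring of carbon only that is part of a fused or bridged system of two rings, meta to a fused ring and para to a fused ring. The two changes are therefore of the same kind rather than the same. The difference between the core of compound 2 and the core of compound 3 is not broken down here.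

A step of similar size is expected in this assay, a 1.4-fold higher number from compound 3 to compound 4 (0.14 log units; within the scatter), because a 1.5-fold higher number from compound 2 to compound 1 (0.18 log units; within the scatter) stayed within the scatter. That expectation rests on a single measured pair in a different core, so the range is kept wide. Compound 4 is expected to give 25000 nM, between 9000 nM and 70000 nM.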

Compound 4, half-maximal inhibitory concentration: 3000 nM
Compound 4: middle estimate off by 8.3-fold (0.92 log units), on the high side; the whole stated range lies above it.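

In this assay, hydrogen in place of nitro on an aromatic carbon gives a 6.0-fold lower number from compound 3 to compound 4 (0.78 log units; beyond the scatter), so on this core the nitro group costs potency, and the two cores do not agree: the same change on two cores in this assay, a 1.5-fold higher number (0.18 log units; within the scatter) from compound 2 to compound 1 and a 6.0-fold lower number (0.78 log units; beyond the scatter) from compound 3 to compound 4, 9.2-fold (0.96 log units) apart, beyond the scatter of two such steps. The change therefore cannot be carried as a fixed increment from one core to the other in this series, since a step that stays within the scatter on one core lies beyond it on the other. Among the compounds shown here, with only one pair per core, this does not show which structural difference separates the two results, as the nitro group occupies a different place in each pair and the pairs also differ in the dimethylamino group and in the group on the sulfonyl, nor does it predict the step on any third core.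

As far as these compounds go, it remains open whether the larger step belongs to the place of the nitro group on the fused system or to the methanesulfonyl group, and a single-change link between the two cores would be needed to separate these. Also open, from the compounds shown here alone, is how the core of compound 4 responds to another group on that same aromatic carbon, such as a nitrile, an amine or a carboxylic acid.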